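Working notes: replacing the chlorine-bearing group of compound 2

This account rests on a few compounds, and the source may have more. Where it says the series, first, only, none or still open, it means among the compounds named here.

Of the compounds shown here, three have been measured in a functional assay on MGC-803 cells (Homo sapiens) for antiproliferative activity, read by MTT assay, with a stated time of 72 h; a lower number here means a stronger inhibitor, a higher number a weaker inhibitor. Compound 1 (`C#CCSc1nc(N/N=C/c2ccc(N(C)C)cc2)c2nnn(Cc3ccccc3)c2n1`) gives 7620 nM, compound 2 (`CCCSc1nc(N/N=C/c2ccccc2Cl)c2nnn(Cc3ccccc3)c2n1`) gives 10900 nM, and compound 3 (`CCCSc1nc(N/N=C(\C)c2ccccc2O)c2nnn(Cc3ccc(O)cc3)c2n1`) gives 7680 nM. Compound 2 lies within the usual scatter of both other compounds, so the three values form one group and support no ranking. No two of these compounds differ in only one place, so no single change has a measured step.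

The next compound for this assay is compound 4 (`CCCSc1nc(N/N=C(\C)c2ccccc2)c2nnn(Cc3ccccc3)c2n1`). Compared with compound 2, it carries this change: a group of 9 heavy atoms (8 carbon, 1 nitrogen; one six-membered aromatic ring of carbon only) in place of a group of 9 heavy atoms (7 carbon, 1 nitrogen, 1 chlorine; one six-membered aromatic ring of carbon only), on a nitrogen on an aromatic ring.

The three measured compounds differ from one another in several places, yet their values stay within the scatter of each other. That gives no basis for expecting a large effect from this one change, although three compounds make a thin basis for any expectation. No step beyond the scatter is expected in either direction. The estimated 1.2-fold lower number from compound 2 to compound 4 (0.08 log units; within the scatter) stays within the scatter. Compound 4 is expected at 9000 nM, with an estimated range from 4000 nM to 20000 nM.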

Compound 4, half-maximal inhibitory concentration: 25400 nM
Estimate against measurement, compound 4: 2.8-fold (0.45 log units) below, outside the stated range (above it).
By their numbers in this assay, from the lowest: compounds 1, 3 and 2 (each within the scatter of the next); then compound 4.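

In this assay, among the compounds shown here, the exchange at this nitrogen on an aromatic ring gives a 2.3-fold higher number from compound 2 to compound 4 (0.37 log units; beyond the scatter), the first step measured between compounds that differ in one place, and the first to lie beyond the scatter. It shows that this place can respond to a modest change: the group of 9 heavy atoms bearing the chlorine and the group of 9 heavy atoms without it share one six-membered aromatic ring of carbon only, 1 double bond outside aromatic rings, 0 hydrogen-bond donors and 1 hydrogen-bond acceptor, yet the replacement goes with a weaker compound in this assay. No measurement at hand offers an explanation for this step.

With both the chlorine and the carbon count changing in a single step, the compounds shown do not separate the loss of the chlorine from the gain of the carbon. Also open, on these data alone, is how the assay would respond to a group carrying bromine, methoxy, an amine or a carboxylic acid at this place, and whether the same exchange would give a similar step on the core of compound 1 or compound 3.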